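From Trifluoromethyl to Trifluoromethoxy on the Shared Core

A few compounds are considered here, and "the series" means these few. Any claim that something is new, unique, unknown or untested is made for them only; others in the source may bear on it.

Of the compounds shown here, three built on a shared core have been tested in a functional assay on HeLa cells (Homo sapiens) for inhibition; on this read-out lower numbers stand for stronger inhibition and higher numbers for weaker inhibition. For the measured compounds named here, compound 2 `Oc1ccccc1-c1cc(-c2ccccc2C(F)(F)F)cc(-c2ccccc2O)n1` is the only one that yields a number: in this assay compound 2 shows 5800 nM. For compound 1 `Oc1ccccc1-c1cc(-c2ccccc2F)cc(-c2ccccc2O)n1` the result is only a limit of the assay, > 50000 nM. For compound 3 `Oc1ccccc1-c1cc(-c2cccc(C(F)(F)F)c2)cc(-c2ccccc2O)n1` the result is likewise a limit, > 50000 nM. Going by the values given here, two measured steps touch compound 2. Exchanging fluoro for trifluoromethyl gives an at least 8.6-fold lower number from compound 1 to compound 2 (0.93 log units; beyond the scatter), and moving the trifluoromethyl group to another position gives an at least 8.6-fold higher number from compound 2 to compound 3 (0.93 log units; beyond the scatter); both are read against (the limit of > 50000 nM in this assay, at which 2 of the 3 values shown sit). Compound 4 `Oc1ccccc1-c1cc(-c2ccccc2OC(F)(F)F)cc(-c2ccccc2O)n1` differs from compound 2 by trifluoromethoxy in place of trifluoromethyl on an aromatic carbon. Among the compounds with values here, no measured step swaps one of these two groups for the other at the same position, so the change is expected to stay within the scatter or to weaken inhibition only modestly, which would mean a 1.4-fold higher number from compound 2 to compound 4 (0.14 log units; within the scatter). Compound 4 is therefore estimated at 8000 nM, with a range from 3000 nM to 25000 nM.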

Compound 4, half-maximal inhibitory concentration: 9750 nM
The estimate for compound 4 lay 1.2-fold (0.09 log units) below the measured number; the measured number falls inside the stated range.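

In this assay, trifluoromethoxy at this place, ortho to a large group, gives a 1.7-fold higher number from compound 2 to compound 4 (0.23 log units; within the scatter), so compound 2 and compound 4 cannot be told apart, and the oxygen that enters, with its hydrogen-bond acceptor, brings no difference that the assay can resolve. The gain over fluoro is also no longer tied to trifluoromethyl alone, since the second group gives an at least 5.1-fold lower number from compound 1 to compound 4 (0.70 log units; beyond the scatter). That step has a floor rather than a fixed size, as compound 1 gives only a limit of the assay: the limit of > 50000 nM in this assay, at which 2 of the 4 values shown sit.

Still open, from the compounds shown here alone, is whether the fluorines matter at this place, which a methyl or methoxy group on the same carbon could show. Also open, going by these compounds, is whether trifluoromethoxy, moved to the ring position that trifluoromethyl holds in compound 3, would behave as trifluoromethyl does there.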